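The source may report more compounds than this note shows. Statements on the series, on what has been measured and on what is new or still open speak of the compounds shown alone.

Among the compounds with values here, compound 1 `Cc1cc(C2=NN(c3ccc(S(C)(=O)=O)cc3)C(=O)CC2)ccc1O` gives 60.5% in a functional assay on the whole organism (strain Wistar) for inhibition, with Rattus norvegicus as the target, read by paw edema, with stated times of 30 min and 5 h, at a dose of 0.05 mmol/kg by the oral route (on this read-out higher numbers stand for more inhibition at the one dose given (going by the name of the read-out) and lower numbers for less inhibition), the second highest of the three numbers measured so far. Compound 3 `CCc1ccc(C2=NN(c3ccc(S(C)(=O)=O)cc3)C(=O)CC2)cc1` gives 65.7%, and the step of a number 5.2 percentage points higher from compound 1 to compound 3 (within the scatter) lies within the scatter. Compound 2 `CS(=O)(=O)c1ccc(N2N=C(c3ccccc3)CCC2=O)cc1` gives 47.3%, and the step of a number 13.2 percentage points lower from compound 1 to compound 2 (beyond the scatter) lies beyond it. Compound 4 `CS(=O)(=O)c1ccc(N2N=C(c3ccc(Cl)cc3)CCC2=O)cc1` differs from compound 1 by 4-chlorophenyl in place of 4-hydroxy-3-methylphenyl on a carbon with a double bond to nitrogen. Within the data shown here, two measured steps bear on this change: the replacement of the 4-hydroxy-3-methylphenyl by a bare phenyl in a number 13.2 percentage points lower from compound 1 to compound 2 (beyond the scatter), and ethyl in place of hydrogen on an aromatic carbon in a number 18.4 percentage points higher from compound 2 to compound 3 (beyond the scatter). The 4-chlorophenyl carries a group on the ring as the 4-ethylphenyl does, so these two steps pull in opposite directions, and for compound 4 the expected step of a number 2.5 percentage points lower from compound 1 to compound 4 (within the scatter) should stay within the scatter. Compound 4 is therefore estimated at 58%, with a range from 42% to 72%.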

Compound 4, a percentage reported as inhibition, in the whole organism at one dose (the size of the read-out at that dose, not a potency): 36.8%
Compound 4: middle estimate off by 21.2 percentage points, on the high side, outside the stated range (below it).
By their numbers in this assay, from the lowest: compound 4; then compound 2; then compounds 1 and 3 (each within the scatter of the next).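

In this assay, a group on this ring does not by itself raise the number: chloro in place of hydrogen gives a number 10.5 percentage points lower from compound 2 to compound 4 (beyond the scatter), whereas ethyl in place of hydrogen went the other way. Chloro in place of ethyl gives a number 28.9 percentage points lower from compound 3 to compound 4 (beyond the scatter) and 4-chlorophenyl in place of 4-hydroxy-3-methylphenyl gives a number 23.7 percentage points lower from compound 1 to compound 4 (beyond the scatter), so at this position the outcome depends on which group is present. No measurement here accounts for the difference between chloro and ethyl. From the compounds shown here alone, whether a methoxy or an amino group in the place of the chloro would follow chloro or ethyl stays open.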